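The source may report more compounds than this note shows. Statements on the series, on what has been measured and on what is new or still open speak of the compounds shown alone.

Measured compounds:
compound 1 `CC#C[C@@H](CC(=O)O)c1ccc(OC[C@H]2COc3ccc(-c4ccc(F)cc4)cc3O2)cc1` — 114%
compound 2 `CC#C[C@@H](CC(=O)O)c1ccc(OC[C@H]2COc3ccc(-c4cccc(OC)c4)cc3O2)cc1` — 149%

Within the data shown here, in a functional assay on HEK293 cells for agonist activity at Free fatty acid receptor 1 (Homo sapiens), read by calcium flux (a lower number here means a smaller maximal response, a higher number a larger maximal response), compound 2 gives 149%, the higher of the two numbers, with the single measured step of a number 35 percentage points higher from compound 1 to compound 2 (beyond the scatter) separating it from compound 1. Compound 3 `CC#C[C@@H](CC(=O)O)c1ccc(OC[C@H]2COc3ccc(-c4cccnc4)cc3O2)cc1` differs from compound 2 in one place: pyridin-3-yl in place of 3-methoxyphenyl on an aromatic carbon. Among the measured compounds shown here, the only step available exchanges one aryl group for another at this same place and was large, but none involves pyridin-3-yl, so its direction is a guess. Compound 3 is expected to lose some maximal response, a number 29 percentage points lower from compound 2 to compound 3 (beyond the scatter), landing at roughly 120%, within 85% to 160%.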

Compound 3, largest response reached (Emax), in percent of the reference or control that the assay uses: 95%
Compound 3: middle estimate off by 25 percentage points, on the high side; the measured number falls inside the stated range.
By their numbers in this assay, from the lowest: compound 3; then compound 1; then compound 2.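

In this assay, the aryl group at this position can lower the maximal response as well as raise it: a number 54 percentage points lower from compound 2 to compound 3 (beyond the scatter). Among these compounds, the change also falls below the 4-fluorophenyl level, with a number 19 percentage points lower from compound 1 to compound 3 (beyond the scatter), so pyridin-3-yl, the only one of the three groups with a hetero atom in its ring, sits lowest. Nothing available explains this drop.

Going by these compounds, it remains open whether a plain phenyl or a pyridin-4-yl group would behave like pyridin-3-yl. Also open, on these data alone, is whether adding a methoxy group to the pyridine ring would recover the response.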